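A few compounds are considered here, and "the series" means these few. Any claim that something is new, unique, unknown or untested is made for them only; others in the source may bear on it.

Three measured compounds share one core: compound 1 `CC/N=C(/NC#N)NCCCn1nc(C)ccc1=O`, compound 2 `CCC/N=C(/NC#N)NCCCn1nc(-c2ccccc2)ccc1=O` and compound 3 `CC/N=C(\S)NCCCn1nc(-c2ccccc2)ccc1=O`. In a functional assay on the whole organism with Rattus norvegicus as the target, at a dose of 100 mg/kg (on this read-out lower numbers stand for less inhibition and higher numbers for more inhibition at the one dose given (going by the name of the read-out)), compound 2 gives 52.9%, the highest of the three; compound 3 gives 39% and compound 1 gives 34.5%. For the measured compounds named here, the only single-point step measured, a number 13.9 percentage points lower from compound 2 to compound 3 (beyond the scatter), alters the group on the amine nitrogen, not the ring, so it does not bear directly on compound 4 `CCC/N=C(/NC#N)NCCCn1nc(C)ccc1=O`, which differs from compound 2 in this way: methyl in place of phenyl on an aromatic carbon. Going by the values given here, no measured pair isolates that swap; compound 1, which carries the methyl together with a different amine chain, sits lower than compound 2. A modest fall is therefore expected, a number 12.9 percentage points lower from compound 2 to compound 4 (beyond the scatter). Compound 4 is estimated at 40%, ranging from 25% to 55%.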

Compound 4, a percentage reported as inhibition, in the whole organism at one dose (the size of the read-out at that dose, not a potency): 17.5%
Beside the measured number, compound 4's estimate is 22.5 percentage points above it, outside the stated range (below it).
By their numbers in this assay, from the lowest: compound 4; then compounds 1 and 3 (each within the scatter of the next); then compound 2.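

In this assay, methyl in place of phenyl on this aromatic carbon gives a number 35.4 percentage points lower from compound 2 to compound 4 (beyond the scatter), so this one position can shift the whole-animal result by a large amount. The amine chain also counts with methyl on the ring: methyl in place of hydrogen on a saturated chain carbon gives a number 17 percentage points lower from compound 1 to compound 4 (beyond the scatter). Nothing available explains either drop.

The compounds shown leave open where an ethyl, a methoxy or an amine on the same carbon would fall between methyl and phenyl. They also leave open whether a longer chain on the amine nitrogen would lower the number further.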